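A few compounds are considered here, and "the series" means these few. Any claim that something is new, unique, unknown or untested is made for them only; others in the source may bear on it.

Compound 2 `O=C(NO)[C@H]1CCCCN1S(=O)(=O)N1CC=C(c2ccc(Br)cc2)CC1` stands at the higher of the two numbers in a functional assay on MONO-MAC-6 cells (Homo sapiens) for inhibition (on this read-out higher numbers stand for weaker inhibition and lower numbers for stronger inhibition), with 1200 nM. Its nearest neighbour, compound 3 `COc1cccc(C2=CCN(S(=O)(=O)N3CCCC[C@@H]3C(=O)NO)CC2)c1`, has 3-methoxyphenyl in place of 4-bromophenyl on a double-bonded ring carbon and gives 260 nM, so a 4.6-fold lower number from compound 2 to compound 3 (0.66 log units; beyond the scatter). Compound 1 `O=C(NO)[C@H]1CCCCN1S(=O)(=O)N1CC=C(c2ccc(Cl)cc2)CC1` gives 430 nM; 480 nM (2 entries); the repeats the several entries of compound 1 in this assay, 430 nM; 480 nM (2 entries) show the reproducibility of this assay, and the values of compound 1 and compound 2 show the 4-chlorophenyl entry lower than the 4-bromophenyl one. Compound 4 `O=C(NO)[C@H]1CCCCN1S(=O)(=O)N1CC=C(c2ccc(Oc3ccccc3)cc2)CC1` carries phenoxy in place of bromo on an aromatic carbon. Among the measured compounds shown here, only the aryl swap from compound 2 to compound 3 bears on this step, and it was modest; no measured step varies the para group further. A step toward weaker inhibition is expected, a 1.5-fold higher number from compound 2 to compound 4 (0.18 log units; within the scatter). For compound 4 the estimate in this assay is 1800 nM, within 450 nM to 7000 nM.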

Compound 4, half-maximal inhibitory concentration: 3300 nM
Estimate against measurement, compound 4: 1.8-fold (0.26 log units) below; low and high end bracket the measured number.
By their numbers in this assay, from the lowest: compound 3; then compound 2; then compound 4.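

Phenoxy in place of bromo on this aromatic carbon gives a 2.8-fold higher number from compound 2 to compound 4 (0.44 log units; beyond the scatter) in this assay. Among the compounds shown here, this is the first step that adds a six-membered aromatic ring at this carbon, and it moves toward weaker inhibition while the number stays measurable. The step can be read against the repeat entries: the several entries of compound 1 in this assay, 430 nM; 480 nM (2 entries)

This single step cannot separate the contribution of the added oxygen from that of the added ring. On these data alone, how an amine or a carboxylic acid at this carbon would read remains open.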